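This account rests on a few compounds, and the source may have more. Where it says the series, first, only, none or still open, it means among the compounds named here.

Going by the values given here, compound 1 `c1ccc(CCc2ccc3c(NCCCNCc4ccco4)ccnc3c2)cc1` is the less soluble of the two measured members: in a physicochemical assay for solubility, with a stated time of 18 h, at pH 7.4 (a lower number here means a less soluble compound, a higher number a more soluble compound), compound 1 gives 4200 nM, while compound 2 `COc1ccc(F)cc1CNCCCNc1ccnc2cc(Oc3ccccc3)ccc12` gives 14500 nM, a higher number lying beyond the scatter. Compound 3 `COc1ccc(Oc2ccc3c(NCCCNCc4ccco4)ccnc3c2)cc1` is the next candidate for this assay; its change from compound 1 is 4-methoxyphenoxy in place of phenethyl on an aromatic carbon. Among the compounds with values here, no measured pair shows this change, so the step is unknown. An upward step of modest size is expected, a 2.1-fold higher number from compound 1 to compound 3 (0.33 log units; beyond the scatter), given that compound 2 carries an aryl ether and reaches 14500 nM. For compound 3 the expected solubility is 9000 nM, within a range from 3000 nM to 27000 nM.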

Compound 3, solubility: 14500 nM
Estimate against measurement, compound 3: 1.6-fold (0.21 log units) below, within the range that was stated.
By their numbers in this assay, from the lowest: compound 1; then compounds 2 and 3 (each within the scatter of the next).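

In this assay, the position on an aromatic carbon, meta to a fused ring and para to a fused ring, now has its first single-place reading: 4-methoxyphenoxy in place of phenethyl gives a 3.5-fold higher number from compound 1 to compound 3 (0.54 log units; beyond the scatter) with the rest of the molecule unchanged. This single step does not separate the contribution of the methoxy group from that of the phenoxy part. No measurement at hand accounts for the step. Still open, on these data alone, is how unsubstituted phenoxy, a lone methoxy or an amine at this position would read on the same side chain.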